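This account rests on a few compounds, and the source may have more. Where it says the series, first, only, none or still open, it means among the compounds named here.

Measured so far:
compound 1, `Cc1ccc(-c2nnc(COc3cnn(C(C)(C)C)c(=O)c3Cl)o2)cc1`: 19900 nM
compound 2, `CCCCn1ncc(OCc2nnc(-c3ccccc3)o2)c(Cl)c1=O`: > 299000 nM

Compound 2, `CCCCn1ncc(OCc2nnc(-c3ccccc3)o2)c(Cl)c1=O`, carries a butyl chain on the shared core. In a functional assay on the whole organism for inhibition, with Mythimna separata as the target, with a stated time of 5 days (on this read-out higher numbers stand for an effect only at larger amounts of compound and lower numbers for an effect already at smaller amounts), compound 2 reaches only the assay limit, > 299000 nM, which is a bound and not a number. Compound 1, `Cc1ccc(-c2nnc(COc3cnn(C(C)(C)C)c(=O)c3Cl)o2)cc1`, gives 19900 nM in this assay. Among the measured compounds shown here, of the two values shown, one sits at the limit (the limit of > 299000 nM in this assay, at which 1 of the 2 values shown sits), so the two compounds differ in more than one place and no step between them can be read.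

Compound 3, `CCn1ncc(OCc2nnc(-c3ccccc3)o2)c(Cl)c1=O`, differs from compound 2 by hydrogen in place of ethyl on a saturated chain carbon, two bonds along the chain from an aromatic nitrogen. For the measured compounds named here, no measured step covers this change. The expected step from compound 2 to compound 3 in this assay is an at least 1.4-fold lower number from compound 2 to compound 3 (0.17 log units; that floor lies within the scatter), within or near the scatter and uncertain because compound 2 stands at > 299000 nM. Compound 3 is estimated at 200000 nM, expected between 40000 nM and 800000 nM.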

Compound 3, half-maximal effective concentration: > 299000 nM
Compound 3 ended at the assay's limit; the forecaster's own chance of this, stated with the estimate: 55%; middle value at least 1.4-fold (0.17 log units) from the limit.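

Compound 2 and compound 3 both stand at the limit in this assay, so no step can be read between them: the limit of > 299000 nM in this assay, at which 2 of the 3 values shown sit.

The compounds shown leave open how butyl and ethyl on the shared core compare in this assay.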